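Methoxy to chloro on an aromatic ring

The source may hold more compounds than are shown below. What is called first, only, known or untested is meant among the compounds shown, and "the series" means these compounds.

In a functional assay on OVCAR-3 cells (Homo sapiens) for cytotoxicity, read by sulforhodamine B assay (a lower number here means a stronger inhibitor of growth, a higher number a weaker inhibitor of growth), compound 1 `CC1=CC[C@@H]([C@@](C)(O)CCCC(C)(C)NC(=S)NN)CC1` gives > 100000 nM, which is a limit of the assay and not a number. Compound 2 `COc1ccc(/C=N\NC(=S)NC(C)(C)CCC[C@](C)(O)[C@@H]2CC=C(C)CC2)cc1` gives 15800 nM, and compound 3 `CC1=CC[C@@H]([C@@](C)(O)CCCC(C)(C)NC(=S)N/N=C\c2cccc(Cl)c2)CC1` gives 26500 nM. Compound 2 therefore stands with compound 3 as one of the two compounds with a real number, and the two agree within the usual scatter. Attaching their aromatic groups gives an at least 6.3-fold lower number from compound 1 to compound 2 (0.80 log units; beyond the scatter) and an at least 3.7-fold lower number from compound 1 to compound 3 (0.57 log units; beyond the scatter).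

Compound 4 `CC1=CC[C@@H]([C@@](C)(O)CCCC(C)(C)NC(=S)N/N=C\c2ccc(Cl)cc2)CC1` has not yet been measured. Its difference from compound 2 is chloro in place of methoxy on an aromatic carbon, so 4-methoxyphenyl becomes 4-chlorophenyl. The closest guide is the exchange of 4-methoxyphenyl for 3-chlorophenyl, which gives a 1.7-fold higher number from compound 2 to compound 3 (0.22 log units; within the scatter). A step beyond the scatter is therefore not expected here. The expected change is a 1.3-fold higher number from compound 2 to compound 4 (0.10 log units; within the scatter). Compound 4 is estimated at 20000 nM, with an expected range of 9000 nM to 45000 nM.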

Compound 4, concentration for total growth inhibition: 12800 nM
Estimate against measurement, compound 4: 1.6-fold (0.19 log units) above, within the range that was stated.
By their numbers in this assay, from the lowest: compounds 4, 2 and 3 (each within the scatter of the next, the first and the last beyond it). At a limit, above all of these: compound 1.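

In this assay, chloro in place of methoxy on this aromatic carbon, para to a large group, gives a 1.2-fold lower number from compound 2 to compound 4 (0.09 log units; within the scatter), so the two groups cannot be told apart at this position. Placing the same chlorine differently, with 4-chlorophenyl in place of 3-chlorophenyl, gives a 2.1-fold lower number from compound 3 to compound 4 (0.32 log units; beyond the scatter), a modest step but the only one among the aromatic compounds that passes the scatter. The 4-chlorophenyl group also gives an at least 7.8-fold lower number from compound 1 to compound 4 (0.89 log units; beyond the scatter), a step that is only a bound, since its starting value is a limit and not a number: the limit of > 100000 nM in this assay, at which 1 of the 4 values shown sits.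

The compounds shown leave open what a plain phenyl ring with no group at this position would give. They also leave open whether an amine or a carboxylic acid here would read like chloro and methoxy or would stand apart from them.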